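Fluoro for Methoxy: Expected Shift for Compound 4

The source may report more compounds than this note shows. Statements on the series, on what has been measured and on what is new or still open speak of the compounds shown alone.

Compound 3 `C=C1CC[C@@H]2[C@](C)(CO)[C@H](O)CC[C@@]2(C)[C@@H]1/C=C/C1=C/C(=C/c2ccc(OC)cc2)OC1=O` stands lowest of the two numbers reported in a functional assay on PC-3 cells (Homo sapiens), read by wound healing assay, with a stated time of 48 h, tested at 10 uM; a higher number here means more inhibition at the concentration tested (going by the name of the read-out), a lower number less inhibition: compound 3 gives 34%, while compound 2 `C=C1CC[C@@H]2[C@](C)(CO)[C@H](O)CC[C@@]2(C)[C@@H]1/C=C/C1=C/C(=C/c2ccc(Cl)cc2)OC1=O` gives 58.5%. Compound 1 `C=C1CC[C@@H]2[C@](C)(COC(=O)CCC(=O)O)[C@H](OC(=O)CCC(=O)O)CC[C@@]2(C)[C@@H]1/C=C/C1=CCOC1=O` was reported as "not active" (no number reported) in this assay, without a number. Among the measured compounds shown here, the only step measured between these compounds is a number 24.5 percentage points lower from compound 2 to compound 3 (beyond the scatter), and it bears directly on the change ahead: compound 4 `C=C1CC[C@@H]2[C@](C)(CO)[C@H](O)CC[C@@]2(C)[C@@H]1/C=C/C1=C/C(=C/c2ccc(F)cc2)OC1=O` differs from compound 3 by fluoro in place of methoxy on an aromatic carbon. This undoes the methoxy that came in from compound 2 to compound 3, so an increase back toward the value of compound 2 is expected, though somewhat smaller, as fluoro is not chloro. Compound 4 is therefore estimated to reach 46%, between 26% and 66%, a rise of a number 12 percentage points higher from compound 3 to compound 4 (beyond the scatter).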

Compound 4, a percentage reported as inhibition, at one concentration (the size of the read-out at that concentration, not a potency): 34.3%
The estimate for compound 4 lay 11.7 percentage points above the measured number, within the range that was stated.
By their numbers in this assay, from the lowest: compounds 3 and 4 (each within the scatter of the next); then compound 2.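

In this assay, changing 4-methoxyphenyl to 4-fluorophenyl gives a number 0.3 percentage points higher from compound 3 to compound 4 (within the scatter), so this assay does not separate these two groups at this position. Fluoro in place of chloro on the same aromatic carbon gives a number 24.2 percentage points lower from compound 2 to compound 4 (beyond the scatter), which shows that the gap from compound 2 is not particular to methoxy, since it appears with fluoro too. Nothing available explains why chloro stands apart from the other two groups. From the compounds shown here alone, it remains open whether bromo, trifluoromethyl or an amine on this carbon would match chloro or instead match fluoro and methoxy.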